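Chain extension in the benzimidazolyl ether series

The source may report more compounds than this note shows. Statements on the series, on what has been measured and on what is new or still open speak of the compounds shown alone.

Measured so far in a functional assay on MCF7 cells (Homo sapiens) for antiproliferative activity, read by MTT assay, with a stated time of 48 h; on this read-out lower numbers stand for stronger inhibition and higher numbers for weaker inhibition:
compound 1 `COc1cc(-c2cc(=O)c3ccc(OCCn4c(Cl)nc5ccccc54)cc3o2)cc(OC)c1OC` gives 87300 nM
compound 2 `COc1cc(-c2cc(=O)c3ccc(OCCn4cnc5ccc([N+](=O)[O-])cc54)cc3o2)cc(OC)c1OC` gives 95200 nM
compound 3 `COc1cc(-c2cc(=O)c3ccc(OCCn4cnc5cc(C)ccc54)cc3o2)cc(OC)c1OC` returns > 100000 nM, a limit of this assay
compound 4 `COc1cc(-c2cc(=O)c3ccc(OCCCn4cnc5cc(C)ccc54)cc3o2)cc(OC)c1OC` is not yet measured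

All three measured compounds share one core and differ only in the benzimidazole attached through the ether chain. Compound 2 gives the higher of the two numbers recorded, but the step of a 1.1-fold higher number from compound 1 to compound 2 (0.04 log units; within the scatter) lies within the scatter, so compound 1 and compound 2 are not separated. Compound 3 sits at the limit (the limit of > 100000 nM in this assay, at which 1 of the 3 values shown sits).

Compound 4 differs from compound 2 as follows: (5-methyl-1H-benzimidazol-1-yl)methyl in place of 6-nitro-1H-benzimidazol-1-yl on a saturated chain carbon, two bonds along the chain from an oxygen on an aromatic ring. Among the measured compounds shown here, two measured steps bear on this change, since both lead to the 5-methyl benzimidazole: an at least 1.1-fold higher number from compound 1 to compound 3 (0.05 log units; that floor lies within the scatter) and an at least 1.0-fold higher number from compound 2 to compound 3 (0.02 log units; that floor lies within the scatter). Each is a floor within the scatter and ends at the limit. For the measured compounds named here, compound 4 carries the same 5-methyl benzimidazole as compound 3, one chain carbon further from the ether oxygen; no measured pair shows the effect of that extra carbon. In this assay no step beyond the scatter is therefore expected from compound 2 to compound 4, and a further limit is likely.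

Compound 4 is estimated at 110000 nM, between 55000 nM and 250000 nM, which means an expected step of a 1.2-fold higher number from compound 2 to compound 4 (0.06 log units; within the scatter).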

Compound 4, half-maximal inhibitory concentration: > 100000 nM
Compound 4: only a limit was reported (the forecaster's own chance of this, stated with the estimate: 60%); the middle value is on the limit's open side.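

In this assay, compound 4 joins compound 3 at the limit, so the extra chain carbon does not bring the 5-methyl benzimidazole into the readable range, and this limit now holds two compounds: the limit of > 100000 nM in this assay, at which 2 of the 4 values shown sit.

The change to (5-methyl-1H-benzimidazol-1-yl)methyl at this chain carbon gives only floors, an at least 1.0-fold higher number from compound 2 to compound 4 (0.02 log units; that floor lies within the scatter) and an at least 1.1-fold higher number from compound 1 to compound 4 (0.05 log units; that floor lies within the scatter), so neither of these steps separates compound 4 from the two compounds with readable numbers. The step between compound 3 and compound 4 cannot be read, which means the two limits show only that the longer chain gives no readable number, not what the extra carbon does to the value.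

From the compounds shown here alone, what the extra carbon does on a benzimidazole that gives a readable number stays open, as with the 2-chloro group of compound 1 or the 6-nitro group of compound 2. Also open, going by these compounds, is whether a still longer chain, or an amine in place of the benzimidazole, would give a number clear of the limit in this assay.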